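Benzyl halogen variation on the hydroxamate series

A few compounds are considered here, and "the series" means these few. Any claim that something is new, unique, unknown or untested is made for them only; others in the source may bear on it.

Measured compounds:
compound 1 `O=C(CCCCCn1cc(Nc2ncc3ccn(Cc4ccccc4F)c3n2)cn1)NO` gives 15.3 nM in an assay on isolated protein for inhibition of protein deacetylase HDAC6 (Homo sapiens), with a stated time of 60 min; a higher number here means a weaker inhibitor, a lower number a stronger inhibitor
compound 2 `O=C(CCCCCn1cc(Nc2ncc3ccn(Cc4ccccc4Cl)c3n2)cn1)NO` gives 45 nM in this assay

Within the data shown here, compound 2 stands as the higher of the two numbers; the only neighbour is compound 1, and the one measured step, a 2.9-fold higher number from compound 1 to compound 2 (0.47 log units; beyond the scatter), is a modest rise beyond the scatter.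

Compound 3 `O=C(CCCCCn1cc(Nc2ncc3ccn(Cc4cccc(F)c4)c3n2)cn1)NO` is not yet measured. It differs from compound 2 by 3-fluorophenyl in place of 2-chlorophenyl on a saturated chain carbon bound to an aromatic nitrogen, so both the halogen and its position on the benzyl ring change at once.

The step from compound 1 to compound 2 is the only one bearing on this: it shows that exchanging fluoro for chloro at the same position shifted the number by a 2.9-fold higher number from compound 1 to compound 2 (0.47 log units; beyond the scatter). Among the measured compounds shown here, the reverse exchange, chloro back to fluoro, is contained in the move to compound 3, but the shift of the halogen to a different ring position has no measured counterpart, so its effect is unknown.

On that basis compound 3 is expected to give a somewhat lower number than compound 2, roughly a 1.8-fold lower number from compound 2 to compound 3 (0.26 log units; within the scatter), with an estimate of 25 nM and a range of 8 nM to 80 nM in this assay.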

Compound 3, half-maximal inhibitory concentration: 13.7 nM
Estimate against measurement, compound 3: 1.8-fold (0.26 log units) above, within the range that was stated.
By their numbers in this assay, from the lowest: compounds 3 and 1 (each within the scatter of the next); then compound 2.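

In this assay the change to 3-fluorophenyl on a saturated chain carbon bound to an aromatic nitrogen gives a 3.3-fold lower number from compound 2 to compound 3 (0.52 log units; beyond the scatter) and places compound 3 with compound 1, leaving compound 2 alone as the weakest of the three. The fluoro series now has a second member, and moving from 2-fluorophenyl to 3-fluorophenyl gives a 1.1-fold lower number from compound 1 to compound 3 (0.05 log units; within the scatter) and so leaves the two fluoro compounds indistinguishable in this measurement. Within these three compounds, the only one set apart carries chlorine rather than fluorine, although the step from compound 2 to compound 3 changes halogen and ring position together, and nothing available explains the differences in these numbers.

As far as these compounds go, whether the higher number of compound 2 belongs to chlorine in general or to the 2-chlorophenyl arrangement remains open, and 3-chlorobenzyl would separate those two readings. Equally open, from the compounds shown here alone, is whether a halogen is needed on this ring at all, a question for the plain benzyl group, and how a methoxy group or a second fluorine would fare at the same place.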